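Chalcone series: isopropyl in place of fluoro for compound 3

The compounds below may be only part of what the source reports. "The series", "measured", "known", "first", "only" and "open" are said of these compounds alone.

Measured so far:
- compound 1 `O=C(COc1ccc(C(=O)/C=C/c2ccc(F)c(F)c2)cc1)N[C@H]1CCOC1=O` — in a functional assay on PC-3 cells (Homo sapiens) for antiproliferative activity, read by MTT assay, with a stated time of 72 h (on this read-out lower numbers stand for stronger inhibition and higher numbers for weaker inhibition), compound 1 gives 21900 nM
- compound 2 `O=C(COc1ccc(C(=O)/C=C/c2ccc(F)cc2)cc1)N[C@H]1CCOC1=O` — in this assay compound 2 gives 15600 nM

For the measured compounds named here, compound 2 and compound 1 are the only two numbers in this assay, and they are not separated: the single step, a 1.4-fold lower number from compound 1 to compound 2 (0.15 log units; within the scatter), stays within the scatter, so neither can be called the more active of the pair.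

Compound 3 `CC(C)c1ccc(/C=C/C(=O)c2ccc(OCC(=O)N[C@H]3CCOC3=O)cc2)cc1` is the next member. Relative to compound 2 the change is isopropyl in place of fluoro on an aromatic carbon; the group sits para to a large group on the ring of carbon only. Going by the values given here, the one measured step bears only loosely on this: it concerns loss of a fluoro and was within the scatter. Among the compounds with values here, no measured step shows what an isopropyl does here, so no direction is supported by the data. A step beyond the scatter is therefore not expected, though the range must be kept wide for an untested group.

Compound 3 is expected at about 12000 nM in this assay, within 4000 nM to 40000 nM. This estimate corresponds to a 1.3-fold lower number from compound 2 to compound 3 (0.11 log units; within the scatter).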

Compound 3, half-maximal inhibitory concentration: 4660 nM
Compound 3: middle estimate off by 2.6-fold (0.41 log units), on the high side; low and high end bracket the measured number.
By their numbers in this assay, from the lowest: compound 3; then compounds 2 and 1 (each within the scatter of the next).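

In this assay, for the compounds shown here, isopropyl in place of fluoro, on an aromatic carbon para to a large group, gives a 3.3-fold lower number from compound 2 to compound 3 (0.52 log units; beyond the scatter) and is the first step to go beyond the scatter, whereas a 1.4-fold lower number from compound 1 to compound 2 (0.15 log units; within the scatter) stayed within it. Measured against the difluorinated compound, 4-isopropylphenyl in place of 3,4-difluorophenyl gives a 4.7-fold lower number from compound 1 to compound 3 (0.67 log units; beyond the scatter) and so reaches the same side, which leaves compound 3 with the lowest number of the three and compounds 1 and 2 unseparated above it. No available evidence bears on what lies behind these steps.

Still open, from the compounds shown here alone, is whether the lower number belongs to isopropyl alone or extends to a methyl, a tert-butyl, a methoxy or a longer alkyl chain on the same carbon, and how an amine or a carboxylic acid would read there. All three compounds also share the rest of the core of compound 1, so whether the gain from isopropyl holds alongside a change elsewhere in that core remains unanswered.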